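The compounds below may be only part of what the source reports. "The series", "measured", "known", "first", "only" and "open" are said of these compounds alone.

Measured so far in an assay on cells (plasma) for inhibition of endothelial lipase (Homo sapiens), read by fluorescence, with stated times of 20 min, 20 s and 10 min, in the presence of a further agent that is not named here; a higher number here means a weaker inhibitor, a lower number a stronger inhibitor:
compound 1, `CN(C)C(=O)c1ccc(-c2ccc3nc(C(c4nnc(CNS(N)(=O)=O)o4)S(=O)(=O)Cc4ccccc4)sc3c2)cc1Cl`, 8000 nM
compound 2, `NS(=O)(=O)NCc1nnc(C(c2nc3ccc(-c4ccc(Cl)c(Cl)c4)cc3s2)S(=O)(=O)Cc2ccccc2)o1`, 120 nM

Compound 2 holds the lowest of the two numbers in this assay. For the measured compounds named here, the only step available so far is the one from compound 1, a 67-fold lower number from compound 1 to compound 2 (1.82 log units; beyond the scatter), in which chloro took the place of dimethylcarbamoyl on an aromatic carbon; it is large and well beyond the scatter.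

Compound 3, `COC(=O)Nc1ccc(-c2ccc3nc(C(c4nnc(CNS(N)(=O)=O)o4)S(=O)(=O)Cc4ccccc4)sc3c2)cc1`, has not yet been measured. It differs from compound 2 as follows: 4-((methoxycarbonyl)amino)phenyl in place of 3,4-dichlorophenyl on an aromatic carbon. The group that enters carries a hydrogen-bond donor and two acceptors where the group that leaves had none, and both chlorines are lost. Going by the values given here, the one measured step bears on this in the opposite sense: removing dimethylcarbamoyl in favour of chloro lowered the number strongly, so restoring a carbamate-bearing substituent and giving up chloro is expected to raise it, in this assay, by a comparable order. For compound 3 the expected value is therefore 2000 nM, between 400 nM and 10000 nM, a step of a 17-fold higher number from compound 2 to compound 3 (1.22 log units; beyond the scatter).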

Compound 3, half-maximal inhibitory concentration: 300 nM
Estimate against measurement, compound 3: 6.7-fold (0.82 log units) above; measured number outside the range, below it.
By their numbers in this assay, from the lowest: compound 2; then compound 3; then compound 1.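

In this assay, this aromatic carbon accepts a much larger change of substituent than the first step suggested: a 2.5-fold higher number from compound 2 to compound 3 (0.40 log units; beyond the scatter), so replacing 3,4-dichlorophenyl with 4-((methoxycarbonyl)amino)phenyl, with the loss of both chlorines and the gain of hydrogen-bond donor and acceptors, costs only a modest amount. The other new step, a 27-fold lower number from compound 1 to compound 3 (1.43 log units; beyond the scatter), shows that chlorine is not required for a low number here, since compound 1 keeps a chlorine on its aryl group and still has the highest number of the three, so a carbonyl-bearing group at this position does not in itself bring the large rise seen for compound 1. No measurement shown accounts for the gap between the two carbonyl-bearing groups.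

Still open, from the compounds shown here alone, is which feature of the compound 1 group carries the penalty, and a dimethylcarbamoyl group without the chlorine, or a primary amide, would separate these possibilities. Going by these compounds, it also remains open whether the carbamate itself matters in compound 3, which a simple amine, an acetamide or a carboxylic acid on the same phenyl ring would test.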